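A few compounds are considered here, and "the series" means these few. Any claim that something is new, unique, unknown or untested is made for them only; others in the source may bear on it.

Measured compounds:
compound 1, `N#C/C(=C\c1ccc([N+](=O)[O-])cc1)C(=O)c1c[nH]c2ccccc12`, 46000 nM
compound 2, `COc1ccc(CNC(=O)/C(C#N)=C/c2ccc(C)o2)cc1`, 58000 nM

Both compounds were tested in a functional assay on A-431 cells (Homo sapiens) for inhibition, read by MTT assay, with a stated time of 72 h; on this read-out higher numbers stand for weaker inhibition of growth and lower numbers for stronger inhibition of growth. In this assay compound 1 gives 46000 nM, and compound 2 gives 58000 nM. The two numbers sit close together; the gap between compound 2 and compound 1 is within the usual scatter of repeated measurements, so neither can be said to inhibit growth more strongly than the other. Compound 3, `COc1ccc(CNC(=O)/C(C#N)=C/c2ccc(Cl)cc2)cc1`, has not yet been measured. It differs from compound 2 in one place: 4-chlorophenyl in place of 5-methylfuran-2-yl on a double-bonded chain carbon bound to a double-bonded chain carbon. Going by the values given here, no pair of measured compounds shows what such a change does in this assay, so there is no measured step to lean on. Among the compounds with values here, with only one compound carrying this core measured, the expectation for compound 3 is a step that stays within the scatter, that is a 1.2-fold lower number from compound 2 to compound 3 (0.06 log units; within the scatter), in no firm direction. Compound 3 is therefore estimated at 50000 nM, within a range from 15000 nM to 150000 nM.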

Compound 3, concentration for 50% growth inhibition: 6000 nM
Compound 3: middle estimate off by 8.3-fold (0.92 log units), on the high side, and the stated range ends above it.
By their numbers in this assay, from the lowest: compound 3; then compounds 1 and 2 (each within the scatter of the next).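

This position is not a silent one: in this assay the change to 4-chlorophenyl in place of 5-methylfuran-2-yl gives a 9.7-fold lower number from compound 2 to compound 3 (0.99 log units; beyond the scatter) and so moves the result towards stronger inhibition of growth. Going by these compounds alone, compound 1 and compound 2 could not be told apart, so this is the first sign that the group on this double-bonded chain carbon can set how strongly growth is inhibited while the rest of the molecule stays the same. No measurement shown here accounts for this gain.

The change replaces the ring and brings in the chlorine atom at once, which leaves open how much of the step belongs to each. A plain phenyl group in the same place would separate the two, and a methyl group on that phenyl ring would show whether another small group can stand in for the chlorine.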